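A Stereochemical Swap on a Methoxycyclohexyl Amide

The source may report more compounds than this note shows. Statements on the series, on what has been measured and on what is new or still open speak of the compounds shown alone.

Compound 2 `CCN(CC)S(=O)(=O)c1ccc(S(=O)(=O)N2CCC[C@@H](C(=O)N[C@H]3CC[C@H](OC)CC3)C2)cc1` is tested in a functional assay on MIA PaCa-2 cells (Homo sapiens) for inhibition, read by MTT assay, with a stated time of 3 days (on this read-out lower numbers stand for stronger inhibition and higher numbers for weaker inhibition), where it gives > 10000 nM; this is a limit of the assay, not a measured number. Compound 1 `CCN(CC)S(=O)(=O)c1ccc(S(=O)(=O)N2CCC[C@@H](C(=O)N3CCS(=O)(=O)CC3)C2)cc1` sits at the same kind of limit, giving > 10000 nM in this assay. Compound 3 `CC(C)S(=O)(=O)c1ccc(S(=O)(=O)N2CCC[C@@H](C(=O)N3CCC(F)(F)CC3)C2)cc1` gives > 3000 nM in this assay, also a limit. Compound 2 therefore stands where every measured compound stands: at a boundary rather than at a value, as the two lines the limit of > 10000 nM in this assay, at which 2 of the 3 values shown sit, and the limit of > 3000 nM in this assay, at which 1 of the 3 values shown sits, show.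

Compound 4 `CCN(CC)S(=O)(=O)c1ccc(S(=O)(=O)N2CCC[C@@H](C(=O)N[C@H]3CC[C@@H](OC)CC3)C2)cc1` differs from compound 2 only in configuration: the two compounds have the same atoms and bonds and differ only in configuration as drawn: 2 of 3 stereo elements differ; a stereocentre at a saturated ring carbon is drawn r in compound 2 and s in compound 4; a stereocentre at a saturated ring carbon is drawn R in compound 2 and S in compound 4

For the measured compounds named here, the one step that exists among measured compounds, a step that the two limits leave unreadable from compound 1 to compound 2, joins two limits and reveals no size, so nothing measured here speaks to a change in configuration alone. No evidence suggests that turning the drawn configuration at the two ring stereocentres would bring compound 4 out of the region where compound 2 lies; the step from compound 2 to compound 4 is expected to be a step that the limit leaves unreadable from compound 2 to compound 4, which is no step beyond the scatter. Compound 4 is therefore expected to give 20000 nM in this assay, with a range from 8000 nM to 60000 nM, most likely reported again only as a limit.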

Compound 4, half-maximal inhibitory concentration: > 10000 nM
Compound 4 ended at the assay's limit; the forecaster's own chance of this, stated with the estimate: 85%; the middle value does not contradict the limit.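

Compound 4, like compound 2 and compound 1, reaches only a limit in this assay, so the steps that join compound 4 to compound 2 and to compound 1 cannot be read. The compounds shown leave open whether the configuration at the two ring stereocentres changes inhibition in this assay at all, as no measured number exists for either compound.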